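Acyloxymethyl ester swap on a phosphonate prodrug and blood half-life

This account rests on a few compounds, and the source may have more. Where it says the series, first, only, none or still open, it means among the compounds named here.

Measured compounds:
compound 1, `COC(=O)CCNC(=O)[C@@H]1O[P@@](=O)(OCOC(=O)c2ccns2)OCC1(C)C`: < 0.16 h
compound 2, `CC(C)(C)OC(=O)CCNC(=O)[C@@H]1OP(=O)(OCOC(=O)C(C)(C)C)OCC1(C)C`: > 1 h

Of the compounds shown here, two have been measured in an ADME assay on blood (Homo sapiens) for pharmacokinetics; on this read-out higher numbers stand for a longer-lived compound and lower numbers for a shorter-lived compound. Compound 1 returns only a limit, < 0.16 h, which is the low end of this assay (the limit of < 0.16 h in this assay, at which 1 of the 2 values shown sits). Compound 2 likewise returns only a limit, > 1 h, at the high end of this assay (the limit of > 1 h in this assay, at which 1 of the 2 values shown sits). The two differ in several places at once, so no single step can be read from them.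

Compound 3, `COC(=O)CCNC(=O)[C@@H]1O[P@@](=O)(OCOC(=O)c2cc(C)nn2C)OCC1(C)C`, is the unmeasured partner of compound 1. The change is 1,3-dimethyl-1H-pyrazol-5-yl in place of 1,2-thiazol-5-yl on a carbonyl carbon, a swap of one five-membered aromatic ring for another at the same carbonyl carbon. The surrounding core and the methyl ester chain stay as in compound 1.

Nothing measured isolates this ring exchange, so the expected step is modest: the half-life of compound 3 is estimated to move by about an at least 1.2-fold higher number from compound 1 to compound 3 (0.09 log units; that floor lies within the scatter), likely staying near the short end. Compound 3 is expected to show 0.2 h, within 0.08 h to 0.6 h.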

Compound 3, half-life: > 1 h
Compound 3: only a limit was reported (the forecaster's own chance of this, stated with the estimate: 50%); middle value at least 5.0-fold (0.69 log units) from the limit.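

In this assay, the ring on this carbonyl carbon proves able to shift the read-out with the shared core and methyl ester chain unchanged: 1,3-dimethyl-1H-pyrazol-5-yl in place of 1,2-thiazol-5-yl gives an at least 6.2-fold higher number from compound 1 to compound 3 (0.79 log units; beyond the scatter). Compound 1 stands at a limit of the read-out: the limit of < 0.16 h in this assay, at which 1 of the 3 values shown sits. Compound 3 stands at the opposite limit, so the step is only a floor: the limit of > 1 h in this assay, at which 2 of the 3 values shown sit.

The compounds shown leave open whether the pyrazole ring itself or its methyl groups carry the step, a question that a plain 1H-pyrazol-5-yl at this carbonyl carbon would address. They also leave open how far the half-life of compound 3 extends past its limit, and how a phenyl ring at this place would compare.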